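Changing the Halogens on a Weak Benzyl Group

A few compounds are considered here, and "the series" means these few. Any claim that something is new, unique, unknown or untested is made for them only; others in the source may bear on it.

In a functional assay on HGC-27 cells (Homo sapiens) for inhibition, read by MTT assay, with a stated time of 72 h (on this read-out higher numbers stand for weaker inhibition and lower numbers for stronger inhibition), compound 1 `Cc1cc(N2CC[C@@H](C)[C@@H](N(C)c3ncnc4[nH]ccc34)C2)n2ncnc2n1` gives 11300 nM and compound 2 `C=CCSc1nc2nc(C)cc(N3CC[C@@H](C)[C@@H](N(C)c4ncnc5[nH]ccc45)C3)n2n1` gives 35200 nM. Compound 3 `Cc1cc(N2CC[C@@H](C)[C@@H](N(C)c3ncnc4[nH]ccc34)C2)n2nc(SCc3ccc(F)c(Cl)c3)nc2n1` gives > 100000 nM, which is a limit of the assay and not a number. Its steps from the other two lie beyond the scatter, so compound 3 is the weakest of the three.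

Compound 4 `Cc1cc(N2CC[C@@H](C)[C@@H](N(C)c3ncnc4[nH]ccc34)C2)n2nc(SCc3ccc(Br)cc3)nc2n1` keeps the shared core and changes one group: 4-bromophenyl in place of 3-chloro-4-fluorophenyl on a saturated chain carbon bound to a sulfur. The 4-bromophenyl sits on a saturated chain carbon bound to a sulfur.

Adding a sulfanyl group weakened inhibition, with a 3.1-fold higher number from compound 1 to compound 2 (0.49 log units; beyond the scatter) for allylsulfanyl and an at least 8.8-fold higher number from compound 1 to compound 3 (0.94 log units; beyond the scatter) for (3-chloro-4-fluorobenzyl)sulfanyl. Replacing vinyl with 3-chloro-4-fluorophenyl gave an at least 2.8-fold higher number from compound 2 to compound 3 (0.45 log units; beyond the scatter). Within the data shown here, no measured step swaps one substituted phenyl for another. Compound 4 retains a benzyl group on the sulfur, so the closest guide is an at least 8.8-fold higher number from compound 1 to compound 3 (0.94 log units; beyond the scatter), and no step beyond the scatter is expected. The estimated step is an at least 1.1-fold lower number from compound 3 to compound 4 (0.04 log units; that floor lies within the scatter). Compound 4 is expected at 90000 nM, with an estimated range of 30000 nM to 250000 nM.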

Compound 4, half-maximal inhibitory concentration: 19500 nM
Compound 4: the middle estimate sits 4.6-fold (0.66 log units) above what was measured; the measured number lies below the stated range.
By their numbers in this assay, from the lowest: compounds 1, 4 and 2 (each within the scatter of the next, the first and the last beyond it). At a limit, above all of these: compound 3.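

Exchanging 3-chloro-4-fluorophenyl for 4-bromophenyl on a saturated chain carbon bound to a sulfur gave an at least 5.1-fold lower number from compound 3 to compound 4 (0.70 log units; beyond the scatter), so the halogens on the phenyl ring can matter here, and a benzyl group on the sulfur does not by itself bring the loss seen with compound 3. The value of compound 3 is a limit of the assay and not a number: the limit of > 100000 nM in this assay, at which 1 of the 4 values shown sits.

Nor does every sulfanyl group weaken inhibition beyond the scatter, since compound 4 goes against that reading of the earlier compounds, with a 1.7-fold higher number from compound 1 to compound 4 (0.24 log units; within the scatter) for (4-bromobenzyl)sulfanyl in place of hydrogen and a 1.8-fold lower number from compound 2 to compound 4 (0.26 log units; within the scatter) for 4-bromophenyl in place of vinyl.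

The compounds shown do not separate the effect of the bromine from that of the chlorine or the fluorine. Going by these compounds, how an unsubstituted phenyl, a 4-chlorophenyl or a phenyl carrying an amine or a carboxylic acid would behave at this place remains open.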